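The source may hold more compounds than are shown below. What is called first, only, known or untested is meant among the compounds shown, and "the series" means these compounds.

Among the compounds with values here, compound 1 `OC[C@H]1O[C@H](Oc2ccc(-c3ccccc3Cl)cc2Cl)[C@@H](O)[C@@H](O)[C@@H]1O` carries a 2-chlorophenyl group and, in a physicochemical assay for solubility, measured as kinetic solubility, with a stated time of 15 h, at pH 7.4 (on this read-out higher numbers stand for higher solubility and lower numbers for lower solubility), gives 28 ug/mL, the highest number of the three measured so far, though its distance to compound 3 stays within the scatter. Compound 2 `Cc1ccc(-c2ccc(O[C@H]3O[C@H](CO)[C@@H](O)[C@H](O)[C@@H]3O)c(Cl)c2)cc1` gives 7.4 ug/mL in this assay, and compound 3 `CC(=O)c1ccc(-c2ccc(O[C@H]3O[C@H](CO)[C@@H](O)[C@H](O)[C@@H]3O)c(Cl)c2)cc1` gives 16 ug/mL. The step of a 3.8-fold lower number from compound 1 to compound 2 (0.58 log units; beyond the scatter) lies beyond the scatter, whereas a 1.8-fold lower number from compound 1 to compound 3 (0.24 log units; within the scatter) does not; between the two, a 2.2-fold higher number from compound 2 to compound 3 (0.33 log units; beyond the scatter). Compound 4 `N#Cc1cccc(-c2ccc(O[C@H]3O[C@H](CO)[C@@H](O)[C@H](O)[C@@H]3O)c(Cl)c2)c1` has not yet been measured. It differs from compound 1 in one place: 3-cyanophenyl in place of 2-chlorophenyl on an aromatic carbon. Both measured replacements of the 2-chlorophenyl group lowered the number, modestly in a 3.8-fold lower number from compound 1 to compound 2 (0.58 log units; beyond the scatter) and only within the scatter in a 1.8-fold lower number from compound 1 to compound 3 (0.24 log units; within the scatter), and the entering 3-cyanophenyl brings one hydrogen-bond acceptor. A downward step of modest size, or none beyond the scatter, is therefore expected here, which is a 1.9-fold lower number from compound 1 to compound 4 (0.27 log units; within the scatter). Compound 4 is expected to give 15 ug/mL in this assay, within a range from 6 ug/mL to 35 ug/mL.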

Compound 4, solubility: 227 ug/mL
Compound 4: the middle estimate sits 15-fold (1.18 log units) below what was measured, and the stated range ends below it.
By their numbers in this assay, from the lowest: compound 2; then compounds 3 and 1 (each within the scatter of the next); then compound 4.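

In this assay the place held by the 2-chlorophenyl group turns out to allow a rise as well: the earlier replacements gave a modest fall or none beyond the scatter, whereas 3-cyanophenyl gives an 8.1-fold higher number from compound 1 to compound 4 (0.91 log units; beyond the scatter) on the same core. The group also stands well clear of the two other replacements, with a 14-fold higher number from compound 3 to compound 4 (1.15 log units; beyond the scatter) and a 31-fold higher number from compound 2 to compound 4 (1.49 log units; beyond the scatter), so compound 4 is the only one shown whose steps to all others lie beyond the scatter. No measurement in hand bears on what lies behind this rise.

The nitrile and its place change together here, so the compounds shown cannot separate them. On these data alone, whether 4-cyanophenyl, 3-acetylphenyl or a phenyl group carrying a carboxylic acid or an amine would give a similar number remains open.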